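Three Ureas at the Limit, a Fourth Awaits Measurement

The source may report more compounds than this note shows. Statements on the series, on what has been measured and on what is new or still open speak of the compounds shown alone.

Compound 1 `CC(=O)c1ccc(NC(=O)Nc2cc(C)nc3ccccc23)cc1` carries an acetyl group on the aromatic ring that hangs off the urea. In an ADME assay on Raji cells (Homo sapiens) for cytotoxicity, with a stated time of 72 h (on this read-out lower numbers stand for an effect already at smaller amounts and higher numbers for an effect only at larger amounts of compound), compound 1 gives > 25000 nM, which is a limit of the measurement rather than a number, so its place among the measured compounds cannot be fixed more closely than that. Compound 2 `Cc1cc(NC(=O)Nc2cccc([N+](=O)[O-])c2)c2ccccc2n1` gives in this assay > 25000 nM, again a limit. Compound 3 `Cc1cc(NC(=O)Nc2cnc3ccccc3c2)c2ccccc2n1` gives in this assay > 25000 nM, also a limit. Among the compounds with values here, all three values shown therefore sit at the limit of > 25000 nM in this assay, at which 3 of the 3 values shown sit, and no step between measured compounds can be stated, since no compound yields a number to compare.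

Compound 4 `Cc1cc(NC(=O)Nc2ccc(SC(F)(F)F)cc2)c2ccccc2n1` shares the core of compound 1 and differs from it by (trifluoromethyl)sulfanyl in place of acetyl on an aromatic carbon. Because every measured value rests at the limit of > 25000 nM in this assay, at which 3 of the 3 values shown sit, the account for compound 4 can only be framed as an expectation: the step that the limit leaves unreadable from compound 1 to compound 4 is expected to be none beyond the usual scatter, with the measurement most likely again returning only a limit. Compound 4 is thus estimated to give in this assay about 30000 nM, within a range from 10000 nM to 100000 nM.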

Compound 4, half-maximal effective concentration: 10000 nM
Estimate against measurement, compound 4: 3.0-fold (0.48 log units) above; low and high end bracket the measured number.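

Within the data shown here, with (trifluoromethyl)sulfanyl in place of acetyl on an aromatic carbon, para to a large group, this assay gives a number rather than a limit for the first time, with compound 4 at 10000 nM. Among these compounds, the change amounts to an at least 2.5-fold lower number from compound 1 to compound 4 (0.39 log units; beyond the scatter), which shows that the read-out can respond to what sits at this place on the six-membered aromatic ring, something the earlier compounds, all resting at a limit, could not show. The size of this step remains only a lower bound, because the starting point in compound 1 is a limit and not a number: the limit of > 25000 nM in this assay, at which 3 of the 4 values shown sit.

The compounds shown leave open how far the true value of compound 1 lies beyond its limit, and so how large the step really is. They also leave open whether the sulfur or the trifluoromethyl part of the new group goes with the lower number, and how an amine, a carboxylic acid or a simple methoxy group at this same place would read out in this assay.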